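Swapping one nitrile for an ester on the pyrrole arm

This account rests on a few compounds, and the source may have more. Where it says the series, first, only, none or still open, it means among the compounds named here.

Compound 1 `Cc1ccc(C)n1-c1cccc(-c2nnn[nH]2)c1` was tested in an ADME assay on MT2 cells (Homo sapiens) for cytotoxicity, read by XTT assay, with a stated time of 4 days (a lower number here means that less compound is tolerated, a higher number that more compound is tolerated), where compound 1 gives 250000 nM. Compound 2 `Cc1cc(C=C(C#N)C#N)c(C)n1-c1cccc(-c2nnn[nH]2)c1` carries a 2,2-dicyanoethenyl group in place of hydrogen on an aromatic carbon. In this assay compound 2 reaches only a limit, > 400000 nM. The step of an at least 1.6-fold higher number from compound 1 to compound 2 (0.20 log units; that floor lies within the scatter) rests on that limit (the limit of > 400000 nM in this assay, at which 1 of the 2 values shown sits), so compound 2 stands at the top of the measured range without a firm number. Compound 3 `CCOC(=O)/C(C#N)=C/c1cc(C)n(-c2cccc(-c3nnn[nH]3)c2)c1C` differs from compound 2 in one place: 2-cyano-2-(ethoxycarbonyl)ethenyl in place of 2,2-dicyanoethenyl on an aromatic carbon. Among the measured compounds shown here, no measured step covers this exchange; the only step available, an at least 1.6-fold higher number from compound 1 to compound 2 (0.20 log units; that floor lies within the scatter), concerns a different change and sits within the scatter, so no shift beyond the scatter is expected in this assay, in either direction. Compound 3 is therefore expected to sit near 400000 nM, within 200000 nM to 800000 nM, most likely again reported as a limit. The expected step of a number no higher from compound 2 to compound 3 (the limit leaves the size open) is essentially flat.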

Compound 3, half-maximal cytotoxic concentration: 76800 nM
Estimate against measurement, compound 3: 5.2-fold (0.72 log units) above; the whole stated range lies above it.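

In this assay, 2-cyano-2-(ethoxycarbonyl)ethenyl in place of 2,2-dicyanoethenyl gives an at least 5.2-fold lower number from compound 2 to compound 3 (0.71 log units; beyond the scatter), the first change at this position shown to lie beyond the scatter. The new group also stands apart from plain hydrogen, with a 3.3-fold lower number from compound 1 to compound 3 (0.51 log units; beyond the scatter), so on this core an arm at this position can lower the tolerated concentration and not only leave it flat or raise it. For compound 2 the value is a limit, so the full size of the exchange stays open: the limit of > 400000 nM in this assay, at which 1 of the 3 values shown sits.

The compounds shown do not tell whether the lower number follows the ethyl chain or the carbonyl itself, and a carboxylic acid or a methyl ester in the same place would separate the two. From the compounds shown here alone, whether a longer ester chain would lower the number further also remains open.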